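The compounds below may be only part of what the source reports. "The series", "measured", "known", "first", "only" and "open" are said of these compounds alone.

Compound 1 `CS/C(=N\C(=O)c1ccco1)NC(=O)c1ccco1`: > 100000 nM
Compound 2 `O=C(/N=C(/NC(=O)c1cccs1)[Se]Cc1ccccc1)c1cccs1`: > 100000 nM
Compound 3 `CS/C(=N\C(=O)c1cccs1)NC(=O)c1cccs1`: 98300 nM

In a functional assay on PC-3 cells (Homo sapiens) for cytotoxicity, read by MTT assay, with a stated time of 72 h (a higher number here means a weaker inhibitor of growth, a lower number a stronger inhibitor of growth), compound 3 gives 98300 nM. For compound 2 the value > 100000 nM is a limit of the assay rather than a number. For compound 1 the value > 100000 nM is likewise a limit. The change from compound 3 to compound 2 is a group of 8 heavy atoms (7 carbon, 1 selenium; one six-membered aromatic ring of carbon only) in place of a group of 2 heavy atoms (1 carbon, 1 sulfur; no ring), on a carbon with a double bond to nitrogen. It gave an at least 1.0-fold higher number from compound 3 to compound 2 (0.00 log units; that floor lies within the scatter), and that floor is set by the limit of > 100000 nM in this assay, at which 2 of the 3 values shown sit. How the core of compound 1 differs from the core of compound 3 is not broken down here.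

Compound 4 `O=C(/N=C(/NC(=O)c1ccco1)[Se]Cc1ccccc1)c1ccco1` has not yet been measured in this assay. Within the data shown here, it differs from compound 1 by a group of 8 heavy atoms (7 carbon, 1 selenium; one six-membered aromatic ring of carbon only) in place of a group of 2 heavy atoms (1 carbon, 1 sulfur; no ring), on a carbon with a double bond to nitrogen, the same change at the same place as the one from compound 3 to compound 2. Beside that earlier step, the expected step is a step that the limit leaves unreadable from compound 1 to compound 4. This rests on compound 1 already sitting at the limit > 100000 nM. It also rests on the measured step of an at least 1.0-fold higher number from compound 3 to compound 2 (0.00 log units; that floor lies within the scatter), which brought no gain. Compound 4 is therefore expected to give about 150000 nM, most likely again only a limit.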

Compound 4, concentration for total growth inhibition: 57600 nM
Estimate against measurement, compound 4: 2.6-fold (0.42 log units) above; measured number below the stated range.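

On the core of compound 1, putting the selenium-containing group with its six-membered aromatic ring in place of methylsulfanyl gives an at least 1.7-fold lower number from compound 1 to compound 4 (0.23 log units; that floor lies within the scatter) in this assay. This step does not establish a gain, and the two cores cannot show whether the change carries from one to the other with the same size: the same change on two cores in this assay, an at least 1.0-fold higher number (0.00 log units; that floor lies within the scatter) from compound 3 to compound 2 and an at least 1.7-fold lower number (0.23 log units; that floor lies within the scatter) from compound 1 to compound 4; the limit leaves it open whether they differ Neither step has an exact size, and both are tied to the same ceiling: the limit of > 100000 nM in this assay, at which 2 of the 4 values shown sit.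

The compounds shown leave open whether the selenium atom or the aromatic ring accounts for any part of the step, and how the change would read on a core whose values all lie within the measurable range. A benzylsulfanyl group or an amine on the same carbon with a double bond to nitrogen would be one way to begin separating these parts.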